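Sulfur-bearing carbon ring in place of methylpyridine on the core

This account rests on a few compounds, and the source may have more. Where it says the series, first, only, none or still open, it means among the compounds named here.

Within the data shown here, compound 3 `Cc1ncccc1N1CCc2c(OC3CCN(C(=O)OC(C)C)CC3)ncnc21` is one of three compounds measured in a functional assay on CHO-K1 cells for agonist activity at Glucose-dependent insulinotropic receptor (Homo sapiens), read by a luciferase reporter, with a stated time of 5 h; a lower number here means that less compound is needed, a higher number that more compound is needed for the effect; in this assay compound 3 gives only the limit > 10000 nM, not a number. Compound 1 `CC(C)OC(=O)N1CCC(Oc2ncnc3c2CCN3c2ccc(S(C)(=O)=O)nc2)CC1` gives 251 nM in this assay. Compound 2 `CC(C)OC(=O)N1CCC(Oc2ncnc3c2CCN3c2ccc(F)cn2)CC1` likewise reaches only the limit > 10000 nM in this assay. The two exchanges away from compound 1 both run far toward the limit: an at least 39-fold higher number from compound 1 to compound 2 (1.60 log units; beyond the scatter), and an at least 39-fold higher number from compound 1 to compound 3 (1.60 log units; beyond the scatter); the third pair, a step that the two limits leave unreadable from compound 2 to compound 3, cannot be read, since both sit at the limit of > 10000 nM in this assay, at which 2 of the 3 values shown sit.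

Compound 4 `CSc1ccc(N2CCc3c(OC4CCN(C(=O)OC(C)C)CC4)ncnc32)cc1F` differs from compound 3 by a group of 9 heavy atoms (7 carbon, 1 fluorine, 1 sulfur; one six-membered aromatic ring of carbon only) in place of a group of 7 heavy atoms (6 carbon, 1 nitrogen; one six-membered aromatic ring with 1 hetero atom), on a nitrogen on an aromatic ring in a ring. Among the measured compounds shown here, the measured steps bear on it only loosely: they show that exchanging the 6-(methylsulfonyl)pyridin-3-yl of compound 1 for either pyridyl group lost potency beyond the scatter, but no measured step leads from compound 3 toward a carbon-only ring carrying a sulfur-bearing group. The entering group shares a sulfur substituent with compound 1 and shares no aromatic nitrogen with compound 2 or compound 3, so some recovery from the limit is expected rather than none, yet with wide uncertainty. Compound 4 is therefore estimated at 2000 nM, within 300 nM to 12000 nM, in this assay, which would mean an expected step of an at least 5.0-fold lower number from compound 3 to compound 4 (0.69 log units; beyond the scatter).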

Compound 4, half-maximal effective concentration: 398 nM
Estimate against measurement, compound 4: 5.0-fold (0.70 log units) above; the range from low to high includes it.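

At this position, on a nitrogen on an aromatic ring in a ring, a number in this assay does not depend on the 6-(methylsulfonyl)pyridin-3-yl group of compound 1, since the carbon-only ring of compound 4 also gives one, with an at least 25-fold lower number from compound 3 to compound 4 (1.40 log units; beyond the scatter) and an at least 25-fold lower number from compound 2 to compound 4 (1.40 log units; beyond the scatter). The comparison with the sulfone shows a 1.6-fold higher number from compound 1 to compound 4 (0.20 log units; within the scatter), so these two groups cannot be told apart here, although only one of them has a nitrogen in its aromatic ring; that ring nitrogen therefore does not decide the outcome on its own. Among the four compounds, the two with sulfur in the entering group give numbers, while compound 2 and compound 3 each stay at a limit, not a number: the limit of > 10000 nM in this assay, at which 2 of the 4 values shown sit.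

In compound 4 the fluorine and the sulfur-bearing methylthio group enter together, so the share of each in the step remains unreadable. As far as these compounds go, whether sulfur is needed at all also stays open, and a carbon-only ring carrying a nitrile or an amine in place of the methylthio group would bear on that question.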